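Extending a bromo-bearing carbamate toward a methoxyphenyl analogue

This account rests on a few compounds, and the source may have more. Where it says the series, first, only, none or still open, it means among the compounds named here.

Of the compounds shown here, three sharing one core have been measured in an assay on HEK293 cells for inhibition of acid ceramidase (Homo sapiens), with a stated time of 10 min; on this read-out higher numbers stand for weaker inhibition and lower numbers for stronger inhibition. Compound 1 `O=C(NCCCCc1ccccc1)n1c(=O)oc2ccccc21` gives 64 nM. Compound 2 `O=C(NCCCCc1ccccc1)n1c(=O)oc2ccc(-c3ccccc3)cc21` gives 42 nM, and compound 3 `O=C(NCCCCc1ccccc1)n1c(=O)oc2ccc(Br)cc21` gives 22 nM. Compound 3 has the lowest number of the three: one step of a 1.9-fold lower number from compound 2 to compound 3 (0.28 log units; within the scatter) stays within the scatter, while the other 2.9-fold lower number from compound 1 to compound 3 (0.46 log units; beyond the scatter) lies beyond it, so compound 3 is only clearly separated from compound 1.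

Compound 4 `COc1ccc(-c2ccc3oc(=O)n(C(=O)NCCCCc4ccccc4)c3c2)cc1` differs from compound 3 in one place: 4-methoxyphenyl in place of bromo on an aromatic carbon. Among the compounds with values here, two measured steps bear on this. The step of a 1.9-fold lower number from compound 2 to compound 3 (0.28 log units; within the scatter) shows that exchanging phenyl for bromo changed little, and the step of a 1.5-fold lower number from compound 1 to compound 2 (0.18 log units; within the scatter) shows that adding phenyl to the core changed little as well. Going back from bromo to an aryl group, now carrying a methoxy, should therefore move the number only slightly, if at all, toward the weaker side. For compound 4 in this assay the expected value is 45 nM, with a range from 20 nM to 110 nM. The step from compound 3 is estimated as a 2.0-fold higher number from compound 3 to compound 4 (0.31 log units; beyond the scatter), within the scatter.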

Compound 4, half-maximal inhibitory concentration: 67 nM
Estimate against measurement, compound 4: 1.5-fold (0.17 log units) below; the measured number falls inside the stated range.
By their numbers in this assay, from the lowest: compounds 3, 2, 1 and 4 (each within the scatter of the next, the first and the last beyond it).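

At this position on the shared core, the bromo and 4-methoxyphenyl compounds are clearly separated in this assay, a 3.0-fold higher number from compound 3 to compound 4 (0.48 log units; beyond the scatter), which the earlier comparison of bromo with plain phenyl, a 1.9-fold lower number from compound 2 to compound 3 (0.28 log units; within the scatter), did not show. Adding the methoxy to the phenyl group gives a 1.6-fold higher number from compound 2 to compound 4 (0.20 log units; within the scatter), and the whole 4-methoxyphenyl group in place of hydrogen gives a 1.0-fold higher number from compound 1 to compound 4 (0.02 log units; within the scatter), so a group of 8 heavy atoms at this position leaves the number within the scatter of that of the unsubstituted core. Nothing given here accounts for the difference between bromo and 4-methoxyphenyl.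

The compounds shown leave open whether this separation is particular to bromo or would also appear with chloro or methyl at this position. They also leave open how an amine or a carboxylic acid on the outer phenyl ring would compare.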